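Aniline in place of a benzylamine on a triazine core

The compounds below may be only part of what the source reports. "The series", "measured", "known", "first", "only" and "open" are said of these compounds alone.

Measured compounds:
compound 1, `Nc1nc(NCc2ccc(F)cc2)nc(-c2ccccc2CO)n1`, 3.97
compound 2, `Cc1cccc(CNc2nc(N)nc(-c3ccccc3CO)n2)c1`, 4.4

Of the compounds shown here, two have been measured in a functional assay on cells for positive allosteric modulation of G-protein coupled receptor 68 (Homo sapiens), read by a luciferase reporter and cAMP accumulation, with a stated time of 30 min, at pH 6.8 and pH 8.3, in the presence of a further agent that is not named here; on this read-out lower numbers stand for lower potency and higher numbers for higher potency (the scale is a negative logarithm). Compound 2 stands highest of the two; its nearest neighbour is compound 1, and the change of 4-fluorophenyl to 3-methylphenyl gave a number 0.43 log units higher from compound 1 to compound 2 (beyond the scatter).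

Compound 3, `Nc1nc(Nc2ccccc2)nc(-c2ccccc2CO)n1`, has not yet been measured. Its difference from compound 2 is phenyl in place of 3-methylbenzyl on a nitrogen on an aromatic ring. Within the data shown here, no measured step bears directly on this change: the only step available, a number 0.43 log units higher from compound 1 to compound 2 (beyond the scatter), swaps one ring for another while the group on the nitrogen keeps the same shape, whereas here the whole group changes. That step was modest, so the expectation rests chiefly on compound 2 itself with a wide margin.

Compound 3 is therefore expected to give about 4.1, within 3.5 to 4.7, a step of a number 0.30 log units lower from compound 2 to compound 3 (within the scatter) that is estimated to stay close to the scatter.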

Compound 3, negative logarithm of the antagonist equilibrium constant: 3.92
For compound 3 the middle estimate is 0.18 log units above the measured one, within the range that was stated.
By their numbers in this assay, from the lowest: compounds 3 and 1 (each within the scatter of the next); then compound 2.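

In this assay the replacement of 3-methylbenzyl by phenyl on the nitrogen gave a number 0.48 log units lower from compound 2 to compound 3 (beyond the scatter) and so did not keep the higher number of compound 2. The replacement of 4-fluorobenzyl by phenyl at the same place gave a number 0.05 log units lower from compound 1 to compound 3 (within the scatter) and thus made no difference beyond the scatter, so the effect of moving to phenyl depends on which benzyl group it replaces, and a chain carbon between ring and nitrogen does not by itself raise the number. Nothing available accounts for the difference between these two replacements.

As far as these compounds go, it remains open whether the methyl group would hold its benefit as 3-methylphenyl directly on the nitrogen. Also open, from the compounds shown here alone, is how a longer chain, such as phenylethyl, would compare with 3-methylbenzyl at this position.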